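Swapping a Triazolyl Ester for a Chlorostyryl Arm

This account rests on a few compounds, and the source may have more. Where it says the series, first, only, none or still open, it means among the compounds named here.

Measured so far:
compound 1, `NS(=O)(=O)c1cc(-c2nnc(CN3CCC(Cc4ccccc4)CC3)o2)c(Cl)cc1SCc1ccccc1`: 0.363 h
compound 2, `NS(=O)(=O)c1cc(-c2nnc(CN3CCN(c4ccc(F)cc4)CC3)o2)c(Cl)cc1SCc1ccccc1`: 0.527 h
compound 3, `CCOC(=O)c1cn(Cc2nnc(-c3cc(S(N)(=O)=O)c(SCc4ccccc4)cc3Cl)o2)nn1`: 0.085 h

All three compounds share a common core and were tested in an ADME assay on microsomes from liver (Homo sapiens) for metabolic stability, read by LC-MS, using NADPH, tested at 5 uM; on this read-out lower numbers stand for a shorter-lived compound and higher numbers for a longer-lived compound. Compound 3 stands lowest of the three numbers. Its nearest neighbour is compound 1, whose number is higher by a gap that is beyond the usual scatter; compound 2 lies further away, also beyond the scatter. Compound 3 is therefore the shortest-lived of the three.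

The next compound, compound 4, is `NS(=O)(=O)c1cc(-c2nnc(/C=C/c3ccc(Cl)cc3)o2)c(Cl)cc1SCc1ccccc1`. It differs from compound 3 in one place: 2-(4-chlorophenyl)ethenyl in place of (4-(ethoxycarbonyl)-1H-1,2,3-triazol-1-yl)methyl on an aromatic carbon.

Among the compounds with values here, no measured pair differing in a single place is available, so the size of this step has to be estimated from where compounds 1 and 2 sit. Both carry other groups at that same place and last longer than compound 3, so compound 4 is expected to move upward in this assay by a step of about a 3.5-fold higher number from compound 3 to compound 4 (0.55 log units; beyond the scatter), beyond the scatter. Compound 4 is expected to give about 0.3 h, within a range from 0.1 h to 0.8 h.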

Compound 4, half-life: 0.207 h
Compound 4: middle estimate off by 1.4-fold (0.16 log units), on the high side; measured number inside the range.
By their numbers in this assay, from the lowest: compound 3; then compounds 4, 1 and 2 (each within the scatter of the next, the first and the last beyond it).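

In this assay, within the data shown here, 2-(4-chlorophenyl)ethenyl in place of (4-(ethoxycarbonyl)-1H-1,2,3-triazol-1-yl)methyl gives a 2.4-fold higher number from compound 3 to compound 4 (0.39 log units; beyond the scatter), the first change confined to this one place that can be read directly. It shows that the half-life responds to the group held on this carbon, and that a longer half-life does not need the hydrogen-bond acceptors of the group that leaves. No measurement shown here explains the step.

As far as these compounds go, the change replaces the whole group at once, so it remains open whether the ester, the nitrogen-containing ring or the chlorophenyl part matters most. A carboxylic acid in place of the ethyl ester, a plain phenyl without the chlorine, or a saturated two-carbon chain in place of the ethenyl link would help separate these parts.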